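Loss of the bromo from compound 1: expected effect

The compounds below may be only part of what the source reports. "The series", "measured", "known", "first", "only" and "open" are said of these compounds alone.

Working notes on a small set of bis-benzylidene compounds sharing one core. Compound 1 `C=CCn1c(=O)/c(=C\c2cc(Br)ccc2F)[nH]c(=O)/c1=C\c1ccccc1OC` is the weaker of the two entries with a number in a functional assay on HeLa cells (Homo sapiens) for cytotoxicity, read by CCK-8 assay, with a stated time of 72 h; a lower number here means a stronger inhibitor, a higher number a weaker inhibitor: compound 1 gives 34600 nM. Compound 2 `COc1ccccc1/C=c1\c(=O)[nH]/c(=C/c2ccccc2Cl)c(=O)n1C` gives 300 nM in this assay, a much lower number, and the gap between the two lies beyond the scatter. Compound 3 `C=CCn1c(=O)/c(=C\c2cc(OC)c(OC)c(OC)c2)[nH]c(=O)/c1=C\c1cccc(Br)c1` is reported in this assay only as "not active" (no number reported), with no number attached, so it adds no scale to the comparison.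

Compound 4 `C=CCn1c(=O)/c(=C\c2ccccc2F)[nH]c(=O)/c1=C\c1ccccc1OC` is not yet measured. It differs from compound 1 by hydrogen in place of bromo on an aromatic carbon. Among the compounds with values here, no measured pair in the set isolates this change, so the expected step rests on the size of the change alone: a single heavy atom removed, with no ring, donor or acceptor involved. The expected step is small, leaning slightly toward a higher number, and most likely within the scatter. For compound 4 the estimate in this assay is 45000 nM, with a range from 15000 nM to 150000 nM. That estimate corresponds to a 1.3-fold higher number from compound 1 to compound 4 (0.11 log units; within the scatter), expected to stay within the scatter.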

Compound 4, half-maximal inhibitory concentration: 45000 nM
Compound 4: the middle estimate sits on the measured number at the digits printed, and the stated range covers the measured number.
By their numbers in this assay, from the lowest: compound 2; then compounds 1 and 4 (each within the scatter of the next).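

In this assay, within the data shown here, hydrogen in place of bromo gives a 1.3-fold higher number from compound 1 to compound 4 (0.11 log units; within the scatter), the first comparison in this set that isolates a change in one place. On the 5-bromo-2-fluorophenyl group of compound 1, at this aromatic carbon meta to a large group and para to the fluoro group, the assay does not separate bromo from hydrogen. No measurement at hand bears on why the exchange leaves the read-out within the scatter.

An amine, a carboxylic acid or a longer chain on this same carbon could still give a different result, as this single exchange tests only bromo against hydrogen. From the compounds shown here alone, whether the exchange reads the same when the other parts of compound 1 differ also remains open.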